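A few compounds are considered here, and "the series" means these few. Any claim that something is new, unique, unknown or untested is made for them only; others in the source may bear on it.

Measured so far:
- compound 1, `CCN(Cc1cccs1)C(=O)COc1ccc(C(F)(F)F)cc1`, in an assay on HEK293 cells for agonist activity at transient receptor potential cation channel subfamily M member 8 (Homo sapiens), read by fluorescence and calcium flux, with a stated time of 15 min; a lower number here means that less compound is needed, a higher number that more compound is needed for the effect: 236 nM
- compound 2, `CCN(Cc1cccs1)C(=O)COc1ccc(C(C)C)cc1`, in this assay: 397 nM

Both compounds share one core, differing only in the group that sits on an aromatic carbon of a six-membered aromatic ring of carbon only. Among the two numbers, compound 2 has the highest one, and its nearest neighbour is compound 1; the step between them, a 1.7-fold higher number from compound 1 to compound 2 (0.23 log units; within the scatter), is within the scatter, so the two cannot be told apart by this measurement.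

Compound 3, `CCN(Cc1cccs1)C(=O)COc1ccc(Cl)cc1`, has not been measured yet. It differs from compound 2 by chloro in place of isopropyl on an aromatic carbon. Among the measured compounds shown here, the only step that bears on this change is the one from compound 1 to compound 2, where one group on the same aromatic carbon was exchanged for another without a shift beyond the scatter. That is thin evidence, and chloro is a different kind of group from either of the two already tried, so a clear direction cannot be derived from the data. No step beyond the scatter is therefore expected in this assay, though the range must be kept wide. Compound 3 is estimated to give 400 nM in this assay, between 150 nM and 1100 nM, which corresponds to an expected step of a 1.0-fold higher number from compound 2 to compound 3 (0.00 log units; within the scatter).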

Compound 3, half-maximal effective concentration: 39 nM
Compound 3: the middle estimate sits 10-fold (1.01 log units) above what was measured; measured number outside the range, below it.
By their numbers in this assay, from the lowest: compound 3; then compounds 1 and 2 (each within the scatter of the next).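

On this aromatic carbon, para to a large group, the choice of group can clearly matter: in this assay, chloro in place of isopropyl gives a 10-fold lower number from compound 2 to compound 3 (1.01 log units; beyond the scatter) and chloro in place of trifluoromethyl gives a 6.1-fold lower number from compound 1 to compound 3 (0.78 log units; beyond the scatter), whereas the earlier exchange between trifluoromethyl and isopropyl alone had shown no shift that could be told apart from the scatter. Compound 3 therefore stands apart from both earlier compounds, with the lowest number of the three, so less of it is needed for the effect, while compounds 1 and 2 remain within the scatter of each other. Nothing measured here accounts for why chloro separates from the other two groups.

On these data alone, whether this low number belongs to chloro alone or is shared by other replacements at this carbon, such as fluoro, bromo, methoxy or an amine, remains open. As far as these compounds go, the rest of the shared core is the same in all three compounds, so it also remains open whether chloro would have a similar effect if another part of that core were changed.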